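The source may hold more compounds than are shown below. What is called first, only, known or untested is meant among the compounds shown, and "the series" means these compounds.

Working notes on the series. In a functional assay on MCF7 cells (Homo sapiens) for cytotoxicity, read by MTT assay, with a stated time of 72 h (on this read-out lower numbers stand for stronger inhibition and higher numbers for weaker inhibition), compound 1 `O=C(Nc1ccc(Oc2ccnc3[nH]ccc23)cc1)c1nn(-c2ccc(Br)cc2)ccc1=O` gives 7890 nM. Compound 2 `O=C(Nc1ccc(Oc2ccnc3[nH]ccc23)cc1)c1nn(-c2ccc(Br)cc2F)ccc1=O` gives 17900 nM in this assay, and compound 3 `O=C(Nc1ccc(Oc2ccnc3[nH]ccc23)c(F)c1)c1nn(-c2ccc(Br)cc2F)ccc1=O` gives 23500 nM. Compound 2 therefore holds the second highest of the three numbers: the change from compound 1 amounted to a 2.3-fold higher number from compound 1 to compound 2 (0.36 log units; beyond the scatter), whereas the further change to compound 3 was a 1.3-fold higher number from compound 2 to compound 3 (0.12 log units; within the scatter), so compound 2 and compound 3 cannot be told apart on this read-out.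

Compound 4 `Cn1ccc2c(Oc3ccc(NC(=O)c4nn(-c5ccc(Br)cc5F)ccc4=O)cc3)ccnc21` differs from compound 2 by methyl in place of hydrogen on an aromatic nitrogen. Going by the values given here, no measured step covers a change of this kind: both steps in hand, a 2.3-fold higher number from compound 1 to compound 2 (0.36 log units; beyond the scatter) and a 1.3-fold higher number from compound 2 to compound 3 (0.12 log units; within the scatter), concern fluoro in place of hydrogen on an aromatic carbon, and one of them stayed within the scatter while the other was modest. Among the compounds with values here, with no direct precedent, compound 4 is expected to sit near compound 2 in this assay, if anything at a somewhat higher number, and the estimated step is a 1.4-fold higher number from compound 2 to compound 4 (0.15 log units; within the scatter). Compound 4 is estimated at 25000 nM, with a range from 8000 nM to 80000 nM.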

Compound 4, half-maximal inhibitory concentration: 19800 nM
Compound 4: the middle estimate sits 1.3-fold (0.10 log units) above what was measured; low and high end bracket the measured number.
By their numbers in this assay, from the lowest: compound 1; then compounds 2, 4 and 3 (each within the scatter of the next).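

In this assay, going by these compounds alone, methyl in place of hydrogen on an aromatic nitrogen of the five-membered aromatic ring gives a 1.1-fold higher number from compound 2 to compound 4 (0.04 log units; within the scatter), the first step that touches this position rather than an aromatic carbon. With compound 2 as the parent, the hydrogen on that nitrogen can therefore be replaced by methyl with no change that this read-out can resolve. Nothing available explains this result.

As far as these compounds go, it remains open whether a larger group at this nitrogen, such as a longer chain or one ending in an amine, would be tolerated in the same way. From the compounds shown here alone, it is also open whether methyl would behave alike on compound 1, at 7890 nM, which lacks the fluoro group of compound 2.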